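Does a chloro on the phenyl change inhibition?

The compounds below may be only part of what the source reports. "The series", "measured", "known", "first", "only" and "open" are said of these compounds alone.

Measured compounds:
Compound 1, `Cc1nnc(-c2nsc3ccccc23)o1`, gives 69% in a functional assay on the whole organism for inhibition, with Rattus norvegicus as the target, with a stated time of 2 h, at a dose of 100 mg/kg by the intraperitoneal route; a higher number here means more inhibition at the dose given (going by the name of the read-out), a lower number less inhibition.
Compound 2, `CCc1nnc(-c2nsc3ccccc23)o1`, gives 10% in this assay.
Compound 3, `c1ccc(-c2nnc(-c3nsc4ccccc34)o2)cc1`, gives 60% in this assay.

Compound 3 stands second highest of the three numbers. Its nearest neighbour is compound 1, with a number 9 percentage points lower from compound 1 to compound 3 (within the scatter), a gap inside the scatter, so the two cannot be ranked. Its furthest is compound 2, with a number 50 percentage points higher from compound 2 to compound 3 (beyond the scatter), a large step beyond the scatter, and the step of a number 59 percentage points lower from compound 1 to compound 2 (beyond the scatter) shows the same low value of compound 2 from the other side.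

The next compound, compound 4, `Clc1ccc(-c2nnc(-c3nsc4ccccc34)o2)cc1`, differs from compound 3 by one change: chloro in place of hydrogen on an aromatic carbon.

Among the measured compounds shown here, none of the three measured steps involves a chloro for a hydrogen, so no step bears directly on this change. For the measured compounds named here, the only step that kept the phenyl, a number 9 percentage points lower from compound 1 to compound 3 (within the scatter), lay within the scatter. With nothing to point either way, no step beyond the scatter is expected in this assay, and the estimated step of no change at the digits printed from compound 3 to compound 4 (within the scatter) is small. Compound 4 is therefore expected to give about 60%, between 35% and 85%.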

Compound 4, a percentage reported as inhibition, in the whole organism at one dose (the size of the read-out at that dose, not a potency): 50%
Compound 4: middle estimate off by 10 percentage points, on the high side; measured number inside the range.
By their numbers in this assay, from the lowest: compound 2; then compounds 4, 3 and 1 (each within the scatter of the next, the first and the last beyond it).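

Going from phenyl to 4-chlorophenyl is the only change shown on the phenyl ring itself, and in this assay it gives a number 10 percentage points lower from compound 3 to compound 4 (within the scatter), so a chloro at this place cannot be told apart from hydrogen. The larger group still keeps the number well clear of the ethyl compound, with a number 40 percentage points higher from compound 2 to compound 4 (beyond the scatter), and it also opens a gap to the methyl compound, with a number 19 percentage points lower from compound 1 to compound 4 (beyond the scatter), a gap that the unsubstituted phenyl did not show in a number 9 percentage points lower from compound 1 to compound 3 (within the scatter). That gap should be read with care, since compound 3 and compound 4 themselves cannot be ranked, and nothing available on these compounds offers an explanation for any of these numbers.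

Going by these compounds, one chloro at one place says little about this ring in general, so it remains open whether a methoxy group, an amine or a carboxylic acid at the same place would also leave the number unchanged within the scatter. On these data alone, it also remains open whether a longer chain, such as propyl, in place of the phenyl would share the low number of compound 2, or whether that value stands alone.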